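The compounds below may be only part of what the source reports. "The series", "measured", "known", "first", "only" and "open" are said of these compounds alone.

Within the data shown here, in an in vitro ADME assay on microsomes from liver (Rattus norvegicus) for metabolic stability (a lower number here means slower removal, a higher number faster removal of the compound), compound 1 `CC(C)NC(=O)[C@H]1CC[C@@H](n2/c(=N/C(=O)c3cc(F)cc(Cl)c3)[nH]c3ccc(CN4CCC(C(C)(C)O)CC4)cc32)CC1` gives 43 mL.min-1.g-1, and compound 2 `CC(C)NC(=O)[C@H]1CC[C@@H](n2/c(=N/C(=O)c3cccc(C#N)c3)[nH]c3ccc(CN4CCC(C(C)(C)O)CC4)cc32)CC1` gives 17 mL.min-1.g-1, the lower of the two numbers measured so far. The next compound, compound 3 `CC(C)NC(=O)[C@H]1CC[C@@H](n2/c(=N/C(=O)c3ccncc3)[nH]c3ccc(CN4CCC(C(C)(C)O)CC4)cc32)CC1`, keeps everything in compound 2 except one group, with pyridin-4-yl in place of 3-cyanophenyl on a carbonyl carbon.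

Among the measured compounds shown here, only one measured step touches that same place: a 2.5-fold lower number from compound 1 to compound 2 (0.40 log units; beyond the scatter). This step is modest but beyond the usual scatter, and it shows that the group on this carbonyl carbon can shift the number in this assay. It is thin evidence, however. It is a single pair, and neither of its compounds carries pyridin-4-yl, so it cannot fix the size or even the direction of the next step. A small further fall seems the most reasonable expectation, with no firm claim beyond that. The expected change is a 1.3-fold lower number from compound 2 to compound 3 (0.12 log units; within the scatter), a step that may not clear the scatter. Compound 3 is estimated at 13 mL.min-1.g-1, with an expected range from 6 mL.min-1.g-1 to 28 mL.min-1.g-1.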

Compound 3, intrinsic clearance in microsomes: < 14 mL.min-1.g-1
Compound 3: only a limit was reported; the forecaster's own chance of this, stated with the estimate: 3%; the middle value lies beyond the limit too.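

In this assay, compound 3, with pyridin-4-yl on the carbonyl carbon, gives a reading that is a limit of the assay and not a number: the limit of < 14 mL.min-1.g-1 in this assay, at which 1 of the 3 values shown sits. This position therefore accepts a six-membered aromatic ring with one hetero atom, and the change from compound 1 now gives a clear result, with an at least 3.0-fold lower number from compound 1 to compound 3 (0.48 log units; beyond the scatter). The change from the nitrile-bearing ring is less decisive, with an at least 1.2-fold lower number from compound 2 to compound 3 (0.08 log units; that floor lies within the scatter), so the floor of this step alone does not establish a real difference between these two compounds, although the reading for compound 3 leaves room for a larger step.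

The true number for compound 3 stays unknown, so the compounds shown cannot tell how far pyridin-4-yl goes beyond 3-cyanophenyl, or whether it matters more than the difference between the two substituted phenyl rings. They also leave open what happens in this assay when the ring nitrogen stands elsewhere, as in pyridin-3-yl, when a second ring nitrogen is present, as in a pyrimidine, or when the pyridine ring carries an amine or a methoxy group.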